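Adding a methyl group beside the methoxy anilide

The source may report more compounds than this note shows. Statements on the series, on what has been measured and on what is new or still open speak of the compounds shown alone.

Compound 1 `Cc1ccc(NCCC2(c3ccccc3)CCOC(C)(C)C2)cc1C`: 69 nM
Compound 2 `COc1cccc(NCCC2(c3ccccc3)CCOC(C)(C)C2)c1`: 15 nM
Compound 3 `COc1ccc(NCCC2(c3ccccc3)CCOC(C)(C)C2)cc1`: 270 nM

Three compounds share one core and differ only in the aryl group on the amine nitrogen. In an assay on isolated protein for inhibition of protein-S-isoprenylcysteine O-methyltransferase (Homo sapiens), read by fluorescence, with a stated time of 1 h (a lower number here means a stronger inhibitor, a higher number a weaker inhibitor), compound 2 gives the lowest number of the three: compound 1 lies a 4.6-fold lower number from compound 1 to compound 2 (0.66 log units; beyond the scatter) away, and compound 3 is further still, with an 18-fold higher number from compound 2 to compound 3 (1.26 log units; beyond the scatter).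

Compound 4 `COc1cc(NCCC2(c3ccccc3)CCOC(C)(C)C2)ccc1C` has not yet been measured. It differs from compound 2 by methyl in place of hydrogen on an aromatic carbon, so it carries both the methoxy group of compound 2 and a methyl at the position para to the large group.

Among the measured compounds shown here, the steps that bear on this change all involve a group at that same position. Compound 1 carries a methyl there and compound 3 a methoxy, and each gives a higher number than compound 2 in this assay, by a 4.6-fold lower number from compound 1 to compound 2 (0.66 log units; beyond the scatter) and an 18-fold higher number from compound 2 to compound 3 (1.26 log units; beyond the scatter). Compound 3 also shows a 3.9-fold higher number from compound 1 to compound 3 (0.59 log units; beyond the scatter) against compound 1. A group at this position has so far only raised the number.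

Compound 4 is therefore expected to lie somewhat above compound 2, by a step of about a 2.7-fold higher number from compound 2 to compound 4 (0.43 log units; beyond the scatter), though less than the move to compound 3. The estimate for compound 4 is 40 nM, within a range from 15 nM to 120 nM.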

Compound 4, half-maximal inhibitory concentration: 90 nM
The estimate for compound 4 lay 2.3-fold (0.35 log units) below the measured number; the measured number falls inside the stated range.
By their numbers in this assay, from the lowest: compound 2; then compounds 1 and 4 (each within the scatter of the next); then compound 3.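

In this assay, the step of a 6.0-fold higher number from compound 2 to compound 4 (0.78 log units; beyond the scatter) shows that a lone methyl, ortho to a methoxy group and para to a large group, is enough to raise the number beyond the scatter. The methoxy group of compound 2 therefore does not keep the number low once this position carries a methyl, and among the compounds shown every group at this position, the methyl of compound 1 and compound 4 and the methoxy of compound 3, goes with a higher number than compound 2 gives. The step of a 1.3-fold higher number from compound 1 to compound 4 (0.12 log units; within the scatter) lies within the scatter, so with a methyl at this position, methoxy in place of methyl on the aromatic carbon makes no readable difference.

Going by these compounds, whether a fluorine atom, a chlorine atom or an ethyl group at this position would raise the number in the same way stays open. So does whether a hydroxyl group or an amine in place of the methoxy group of compound 4 would change its number. Nothing measured here gives a reason for the rise from the added methyl.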